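Swapping Methyl for Methoxy on Two Related Cores

The source may hold more compounds than are shown below. What is called first, only, known or untested is meant among the compounds shown, and "the series" means these compounds.

Of the compounds shown here, three have been tested in a functional assay on A549 cells (Homo sapiens) for antiproliferative activity, read by MTT assay; a higher number here means a weaker inhibitor, a lower number a stronger inhibitor. Compound 1 `COc1ccc(-c2ccnc(Nc3ccc(Cl)cc3Cl)n2)cc1` and compound 2 `Cc1ccc(-c2ccnc(Nc3ccc(Cl)cc3Cl)n2)cc1` share one core, while compound 3 `Cc1cccc(Nc2nccc(-c3ccc(Cl)cc3Cl)n2)c1` is built from the same atoms joined differently; the difference between the two cores is not broken down here. In this assay compound 1 gives 7330 nM, compound 2 gives 164000 nM, and compound 3 gives 18500 nM, which places compound 3 between the other two.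

Within the first core, one change has been measured: methoxy in place of methyl on an aromatic carbon This gave a 22-fold lower number from compound 2 to compound 1 (1.35 log units; beyond the scatter), a large step.

Compound 4 `COc1cccc(Nc2nccc(-c3ccc(Cl)cc3Cl)n2)c1` has not yet been measured. It is made from compound 3 by the same kind of change: methoxy in place of methyl on an aromatic carbon The surroundings differ, though: in the measured pair the group sits para to a large group, in the new pair meta to a large group, and the core is the other one.

Because the measured step of a 22-fold lower number from compound 2 to compound 1 (1.35 log units; beyond the scatter) was large, a lower number is expected for compound 4, but the different core and the meta rather than para placement give reason to expect a smaller step, a 2.6-fold lower number from compound 3 to compound 4 (0.42 log units; beyond the scatter). Compound 4 is therefore estimated to give 7000 nM in this assay, with a likely range from 2000 nM to 25000 nM.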

Compound 4, half-maximal inhibitory concentration: 32200 nM
Compound 4: the middle estimate sits 4.6-fold (0.66 log units) below what was measured, and the stated range ends below it.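

On the core of compound 3, methoxy in place of methyl gave a 1.7-fold higher number from compound 3 to compound 4 (0.24 log units; within the scatter) in this assay, so on this core the swap has no effect that can be told apart from the ordinary variation between repeated measurements. The large gain seen on the other core therefore did not carry over, and the gap between the two results is real rather than a product of measurement noise: the same change on two cores in this assay, a 22-fold lower number (1.35 log units; beyond the scatter) from compound 2 to compound 1 and a 1.7-fold higher number (0.24 log units; within the scatter) from compound 3 to compound 4, 39-fold (1.59 log units) apart, beyond the scatter of two such steps

What this does not show is the reason for the gap: the two pairs differ in their core and also in where the group sits, and two pairs cannot separate those two differences, so no general rule for this swap across other cores can be drawn from them.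

The compounds shown leave open whether methoxy would give a large step on the core of compound 3 if it were placed elsewhere on the same ring. They also leave open how other groups at the same place, such as an amine, a hydroxyl or a longer chain, would compare on each of the two cores.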